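The source may report more compounds than this note shows. Statements on the series, on what has been measured and on what is new or still open speak of the compounds shown alone.

Of the compounds shown here, three have so far been tested in a functional assay on HeLa cells for antagonist activity at 5-hydroxytryptamine receptor 6 (Homo sapiens); a higher number here means a larger maximal response, a lower number a smaller maximal response. Compound 1 `CN1CCN(c2ccc3[nH]nc(S(=O)(=O)c4ccccc4Cl)c3c2)CC1` gives 100% in this assay, level with compound 2 `CN1CCN(c2cccc3c(S(=O)(=O)c4cccc5ccccc45)n[nH]c23)CC1`, which gives 100%; together these are the highest of the three numbers. Compound 3 `CCCn1nc(S(=O)(=O)c2cccc3ccccc23)c2cc(N3CCNCC3)ccc21` gives 99%, a shade lower at the digits shown but within the scatter, so the three values show no trustworthy difference. Compound 4 `CN1CCN(c2ccc3[nH]nc(S(=O)(=O)c4ccc(Cl)cc4)c3c2)CC1` is not yet measured. It differs from compound 1 in one place: 4-chlorophenyl in place of 2-chlorophenyl on a sulfonyl sulfur. Going by the values given here, no measured pair differs in only one place, so no measured step tells what this swap does. Across compounds 1, 2 and 3 the response holds steady despite different aryl groups, so no shift beyond the scatter is foreseen. The step of a number 1 percentage points lower from compound 1 to compound 4 (within the scatter) is expected to lie within the scatter. Compound 4 is estimated at 99%, between 88% and 105%.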

Compound 4, largest response reached (reported as Imax), in percent of the reference or control that the assay uses: 100%
The estimate for compound 4 lay 1 percentage points below the measured number; measured number inside the range.
By their numbers in this assay, from the lowest: compounds 3, 1, 2 and 4 (each within the scatter of the next).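

In this assay the swap of 2-chlorophenyl for 4-chlorophenyl on the sulfonyl sulfur gives no change at the digits printed from compound 1 to compound 4 (within the scatter). Going by these compounds alone, this is the first comparison that changes one place only, and it shows that the response does not distinguish these two chlorophenyl groups. No available data explain this result. As far as these compounds go, it remains open whether an unsubstituted phenyl group would give the same response. The same question applies to a phenyl ring carrying a methoxy group or a carboxylic acid in place of chlorine.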